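From Acetyl to Methyl: One Small Swap

The source may hold more compounds than are shown below. What is called first, only, known or untested is meant among the compounds shown, and "the series" means these compounds.

Among the compounds with values here, in an ADME assay on MT4 cells (Homo sapiens) for cytotoxicity, read by MTT assay (a higher number here means that more compound is tolerated, a lower number that less compound is tolerated), compound 3 `CC(=O)c1ccc(NC(=O)CSc2nncnc2-c2ccccc2Cl)c(Br)c1` gives 34000 nM, the lowest of the three numbers measured so far. Compound 1 `O=C(CSc1nncnc1-c1ccccc1Cl)Nc1ccccc1Br` gives 73000 nM, and compound 2 `O=C(CSc1nncnc1-c1ccccc1Cl)Nc1ccccc1` gives 127000 nM. The next compound, compound 4 `Cc1ccc(NC(=O)CSc2nncnc2-c2ccccc2Cl)c(Br)c1`, matches compound 3 except for one group: it has methyl in place of acetyl on an aromatic carbon, meta to a bromo group and para to a large group (methyl in place of acetyl on an aromatic carbon).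

Two measured steps can be weighed here. The more relevant one, a 2.1-fold lower number from compound 1 to compound 3 (0.33 log units; beyond the scatter), comes from acetyl in place of hydrogen on that same aromatic carbon. The other, a 1.7-fold higher number from compound 1 to compound 2 (0.24 log units; within the scatter), comes from hydrogen in place of bromo, at a different place, so it offers little guidance. Within the data shown here, no measured compound carries methyl at this position, which leaves the effect of this swap uncertain. Compound 1 still offers a reference, since the arrival of acetyl went with a 2.1-fold lower number from compound 1 to compound 3 (0.33 log units; beyond the scatter), and losing that group may reverse part of this change. In this assay, a small rise is therefore expected, with an estimated 1.6-fold higher number from compound 3 to compound 4 (0.21 log units; within the scatter). For compound 4 the estimated value is 55000 nM, with an expected range from 25000 nM to 110000 nM.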

Compound 4, half-maximal cytotoxic concentration: 45000 nM
Estimate against measurement, compound 4: 1.2-fold (0.09 log units) above; measured number inside the range.
By their numbers in this assay, from the lowest: compounds 3, 4, 1 and 2 (each within the scatter of the next, the first and the last beyond it).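

In this assay, methyl in place of acetyl on this aromatic carbon gives a 1.3-fold higher number from compound 3 to compound 4 (0.12 log units; within the scatter) and so stays within the scatter, although three heavy atoms and a hydrogen-bond acceptor leave and one heavy atom enters. Methyl in place of hydrogen on the same carbon gives a 1.6-fold lower number from compound 1 to compound 4 (0.21 log units; within the scatter) and also stays within the scatter, so the hydrogen, methyl and acetyl forms show no clear separation through any single methyl step, even though the acetyl step from hydrogen lay just beyond it. Within the data shown here, the one new step beyond the scatter is a 2.8-fold lower number from compound 2 to compound 4 (0.45 log units; beyond the scatter) with 2-bromo-4-methylphenyl in place of phenyl, a modest change that brings in both bromo and methyl and so cannot be assigned to either group alone.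

As far as these compounds go, it remains open whether an amine, a carboxylic acid or a longer chain on this carbon would shift the number clearly, and whether methyl would behave the same way on a ring without the bromo group. Nothing available explains why these numbers fall where they do.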